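Notes on a chromone series: the chain off the core

The compounds below may be only part of what the source reports. "The series", "measured", "known", "first", "only" and "open" are said of these compounds alone.

Measured so far:
- compound 1, `CCc1c(F)c(N)c2c(=O)cc(-c3ccc(N)c(F)c3)oc2c1F`: 130 nM
- compound 2, `[N-]=[N+]=Nc1c(F)c(N)c2c(=O)cc(-c3ccc(N)c(F)c3)oc2c1F`: 460 nM
- compound 3, `CCC(=O)OCc1c(F)c(N)c2c(=O)cc(-c3ccc(N)c(F)c3)oc2c1F`: 130 nM

All three were tested in a functional assay on MCF7 cells (Homo sapiens) for cytotoxicity, read by neutral red uptake, with a stated time of 3 days; on this read-out lower numbers stand for stronger inhibition and higher numbers for weaker inhibition. Compound 1 stands level with compound 3 at the digits given, and the two together hold the lowest numbers of the three; the furthest from compound 1 is compound 2, with a 3.5-fold higher number from compound 1 to compound 2 (0.55 log units; beyond the scatter).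

The untested compound 4, `CCCOCc1c(F)c(N)c2c(=O)cc(-c3ccc(N)c(F)c3)oc2c1F`, differs from compound 1 by propoxy in place of methyl on a saturated chain carbon bound to an aromatic carbon. Among the measured compounds shown here, the step that bears most directly on this is the one from compound 1 to compound 3, which alters the same saturated chain carbon by attaching an oxygen-linked group, and it reads no change at the digits printed from compound 1 to compound 3 (within the scatter). The step from compound 1 to compound 2 changes a different place, the aromatic carbon itself, and is of limited relevance here. On this basis no step beyond the scatter is expected in this assay for compound 4; the estimated step is a 1.2-fold higher number from compound 1 to compound 4 (0.06 log units; within the scatter). Compound 4 is therefore expected to give about 150 nM, within the range 70 nM to 350 nM.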

Compound 4, half-maximal inhibitory concentration: 1200 nM
The estimate for compound 4 lay 8.0-fold (0.90 log units) below the measured number; the whole stated range lies below it.
By their numbers in this assay, from the lowest: compounds 1 and 3 (each within the scatter of the next); then compound 2; then compound 4.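

In this assay, propyl in place of propanoyl on the oxygen gives a 9.2-fold higher number from compound 3 to compound 4 (0.97 log units; beyond the scatter), so the flat reading at this saturated chain carbon holds for the propanoyloxy group and does not extend to every oxygen-linked chain. Propoxy in place of methyl gives a 9.2-fold higher number from compound 1 to compound 4 (0.97 log units; beyond the scatter), which shows that an oxygen-linked chain at this carbon can carry a clear loss, although the propanoyloxy group of compound 3 does not. The propoxymethyl group also ends beyond azido on the aromatic carbon, at a 2.6-fold higher number from compound 2 to compound 4 (0.42 log units; beyond the scatter), so azido no longer marks the high end of the series.

Nothing measured here accounts for the gap between the propanoyl and propyl ends on that oxygen. From the compounds shown here alone, whether a methoxy group, a longer ether chain or an amine on the same carbon would read like compound 3 or like compound 4 remains open.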